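A few compounds are considered here, and "the series" means these few. Any claim that something is new, unique, unknown or untested is made for them only; others in the source may bear on it.

Working notes on the series.

Two members have been run so far. Compound 1 `CC1=NC(C)=C(C(=O)O)C(c2cccc(C(=O)O)c2)/C1=C(\O)OC/C=C/c1ccccc1` and compound 2 `CC1=NC(C)=C(C(=O)O)C(c2cccc(F)c2)/C1=C(\O)OC/C=C/c1ccccc1` share one core and differ at a single aromatic carbon. In a functional assay on thoracic aorta for inhibition of Voltage-gated L-type calcium channel (Rattus norvegicus) (on this read-out lower numbers stand for stronger inhibition and higher numbers for weaker inhibition), compound 1 gives > 10000 nM, which is a limit of the assay rather than a number (the limit of > 10000 nM in this assay, at which 1 of the 2 values shown sits). In this assay, within the data shown here, compound 2 gives 20 nM, the only number in the set. The other value shown, that of compound 1, is a limit. Among the measured compounds shown here, the measured step of an at least 500-fold lower number from compound 1 to compound 2 (2.69 log units; beyond the scatter) is the sole step available and it is large, so compound 2 stands as the one fixed point against which new members are read.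

Compound 3 `CC1=NC(C)=C(C(=O)O)C(c2cccc(Br)c2)/C1=C(\O)OC/C=C/c1ccccc1` is the next member. It differs from compound 2 by bromo in place of fluoro on an aromatic carbon of a six-membered aromatic ring of carbon only, meta to a large group. For the measured compounds named here, no measured step exchanges one halogen for another; the only measured step, from compound 1 to compound 2, swaps carboxy for fluoro and is of a different kind. For compound 3 a step of a 1.3-fold lower number from compound 2 to compound 3 (0.12 log units; within the scatter) in this assay is therefore expected, most likely within the scatter. Compound 3 is estimated at 15 nM, between 4 nM and 60 nM.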

Compound 3, half-maximal inhibitory concentration: 10 nM
The estimate for compound 3 lay 1.5-fold (0.18 log units) above the measured number; measured number inside the range.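

In this assay, bromo in place of fluoro on this aromatic carbon gives a 2.0-fold lower number from compound 2 to compound 3 (0.30 log units; within the scatter), so the two halogens cannot be told apart at this position, and the change from 3-fluorophenyl to 3-bromophenyl leaves the read-out where it was within the scatter. Bromo in place of carboxy gives an at least 1000-fold lower number from compound 1 to compound 3 (3.00 log units; beyond the scatter), a large step in the same direction as an at least 500-fold lower number from compound 1 to compound 2 (2.69 log units; beyond the scatter), so the gap to compound 1 is not particular to fluoro but holds for both halogens shown. The size of both steps remains open-ended, since compound 1 stands at a limit and not at a number: the limit of > 10000 nM in this assay, at which 1 of the 3 values shown sits.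

The compounds shown hold only carboxy, fluoro and bromo at this position, so it stays open whether chloro, methyl or methoxy would read like the halogens, and whether an amine or a primary amide would read like carboxy. Nor do they show how far the read-out of compound 1 lies past its limit, or whether an ester of the carboxy group would stay as far from compound 2 and compound 3.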